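A few compounds are considered here, and "the series" means these few. Any claim that something is new, unique, unknown or untested is made for them only; others in the source may bear on it.

Measured compounds:
- compound 1, `CCCCCCCCCCCCCC[C@H](O)[C@H](CO[Si](c1ccccc1)(c1ccccc1)C(C)(C)C)NC(=O)OC(C)(C)C`: -37.5%
- compound 2, `CCCCCCCCCCCCCC[C@H](OCOC)[C@H](CN(CC)CC)NC(=O)OC(C)(C)C`: 0.84%

In a functional assay on MDA-MB-231 cells (Homo sapiens) for antiproliferative activity, read by sulforhodamine B assay, with a stated time of 48 h, tested at 10 uM (on this read-out higher numbers stand for more inhibition at the one concentration tested (going by the name of the read-out) and lower numbers for less inhibition), compound 2 gives 0.84%, the higher of the two numbers in hand; compound 1 sits a good way lower, a gap beyond the usual scatter. Both numbers say little inhibition at the one concentration tested, compound 1 even less than none.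

Compound 3, `CCCCCCCCCCCCCC[C@H](OCOC)[C@H](CN1CCCCC1)NC(=O)OC(C)(C)C`, has not been measured in this assay. It differs from compound 2 in one place: piperidin-1-yl in place of diethylamino on a saturated chain carbon, two bonds along the chain from an amide-type nitrogen. Among the compounds with values here, no step between measured compounds covers a change of this kind, so the expected size rests on the structural change alone. Replacing diethylamino with piperidin-1-yl on the same saturated chain carbon keeps the chain, the carbamate and the methoxymethyl ether of compound 2 untouched, and a step within the scatter, in either direction, is expected. On that basis compound 3 is estimated at 4%, with a likely range from -14% to 22%. The step from compound 2 to compound 3 that this estimate means is a number 3.2 percentage points higher from compound 2 to compound 3 (within the scatter), a step expected to be no larger than the scatter.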

Compound 3, a percentage reported as inhibition, at one concentration (the size of the read-out at that concentration, not a potency): 9.84%
The estimate for compound 3 lay 5.8 percentage points below the measured number; measured number inside the range.
By their numbers in this assay, from the lowest: compound 1; then compounds 2 and 3 (each within the scatter of the next).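

In this assay, within the data shown here, piperidin-1-yl in place of diethylamino on a saturated chain carbon, two bonds along the chain from an amide-type nitrogen, gives a number 9 percentage points higher from compound 2 to compound 3 (within the scatter), the first step that can be read at one place. Tying the open diethylamino group into a six-membered non-aromatic ring therefore does not separate the two compounds on this read-out, and at the one concentration tested both remain at little inhibition. No measurement on hand accounts for this result.

Going by these compounds, whether a morpholine ring, a primary amine or a carboxylic acid at this place would give a step beyond the scatter remains open. Compound 1 differs from the others in more than one place, so steps to it cannot be read.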